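The source may report more compounds than this note shows. Statements on the series, on what has been measured and on what is new or still open speak of the compounds shown alone.

Series notes. Three compounds have numbers in a functional assay on CHO-K1 cells with Glucose-dependent insulinotropic receptor (Homo sapiens) as the target, read by a luciferase reporter, with a stated time of 5 h; a higher number here means a larger maximal response, a lower number a smaller maximal response: compound 1 `CC(C)(C)OC(=O)N1CCC(Oc2cccc3c2ccn3-c2ccc(S(C)(=O)=O)cc2)CC1` gives 28%, compound 2 `CC(C)OC(=O)N1CCC(Oc2ncnc3c2CCN3c2ccc(S(C)(=O)=O)cc2)CC1` gives 154%, and compound 3 `COC(=O)N1CCC(Oc2ncnc3c2CCN3c2ccc(S(C)(=O)=O)cc2F)CC1` gives 119%. Compound 3 stands second of the three in this assay; its nearest neighbour is compound 2, whose number lies higher by more than the scatter, and compound 1 lies far lower, also beyond the scatter. Among the compounds with values here, no pair of measured compounds differs in one place only, so no single step is established. Compound 4 `CC(C)(C)COC(=O)N1CCC(Oc2ncnc3c2CCN3c2ccc(S(C)(=O)=O)cc2F)CC1` differs from compound 3 by one change: tert-butyl in place of hydrogen on a saturated chain carbon bound to an oxygen next to a carbonyl group. Within the data shown here, no measured step isolates this change. Compound 4 is expected to show a modest rise, a number 11 percentage points higher from compound 3 to compound 4 (beyond the scatter), within or just beyond the scatter. The estimate for compound 4 in this assay is 130%, ranging from 90% to 170%.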

Compound 4, largest response reached (reported as percent of maximum), in percent of the reference or control that the assay uses: 80%
Estimate against measurement, compound 4: 50 percentage points above; measured number below the stated range.
By their numbers in this assay, from the lowest: compound 1; then compound 4; then compound 3; then compound 2.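

Within the data shown here, this is the first step that can be read at a single place: in this assay, tert-butyl in place of hydrogen on a saturated chain carbon bound to an oxygen next to a carbonyl group gives a number 39 percentage points lower from compound 3 to compound 4 (beyond the scatter). The maximal response therefore depends on what stands at this place, and here the larger group lowers it. Nothing measured on these compounds accounts for the fall.

One step cannot show whether the response falls gradually with chain size or depends on branching. An unbranched chain such as n-butyl at the same place would help separate these readings.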